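Swapping isopropylamino for dimethylamino at the assay limit

The source may report more compounds than this note shows. Statements on the series, on what has been measured and on what is new or still open speak of the compounds shown alone.

Measured in a functional assay on SW-620 cells (Homo sapiens) for inhibition, read by MTT assay, with a stated time of 72 h; on this read-out lower numbers stand for stronger inhibition and higher numbers for weaker inhibition:
- compound 1 `COc1cc(Oc2cccc(Nc3ccccc3)c2)cc(OC)c1CN[C@H](C)c1ccccc1`: 18700 nM
- compound 2 `COc1cc(Oc2cccc(Nc3ccccc3)c2)cc(OC)c1CNCc1ccc(Cl)cc1`: 6340 nM
- compound 3 `COc1cc(Oc2cccc(Nc3ccccc3)c2)cc(OC)c1CNC(C)C`: > 20000 nM

Compound 3 gives > 20000 nM, which is a limit of the assay and not a number. Compound 4 `COc1cc(Oc2cccc(Nc3ccccc3)c2)cc(OC)c1CN(C)C` is not yet measured. It differs from compound 3 by dimethylamino in place of isopropylamino on a saturated chain carbon bound to an aromatic carbon.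

Within the data shown here, two measured steps bear on this position: an at least 3.1-fold higher number from compound 2 to compound 3 (0.49 log units; beyond the scatter), and an at least 1.0-fold higher number from compound 1 to compound 3 (0.02 log units; that floor lies within the scatter). The first is the only one of the two beyond the scatter, and it removes 4-chlorobenzyl, a group absent from compound 4. Neither step involves dimethylamino, so they offer only indirect guidance. No step beyond the scatter is expected in this assay, and the expected step is a step that the limit leaves unreadable from compound 3 to compound 4. For compound 4 the estimated value is 24000 nM, with an expected range of 11000 nM to 50000 nM.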

Compound 4, half-maximal inhibitory concentration: > 20000 nM
Compound 4: a limit, no number; the forecaster's own chance of this, stated with the estimate: 65%; the middle value lies beyond the limit too.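

In this assay compound 4 gives > 20000 nM, a limit of the assay and not a number. With dimethylamino at this place the series shows an at least 3.1-fold higher number from compound 2 to compound 4 (0.49 log units; beyond the scatter) and an at least 1.0-fold higher number from compound 1 to compound 4 (0.02 log units; that floor lies within the scatter), so a second small amine without an aromatic ring joins isopropylamino at the limit, and the tertiary amine, with no hydrogen-bond donor, brings no readable gain over the secondary one. The step from compound 3 to compound 4 cannot be read because both values lie at the limit: the limit of > 20000 nM in this assay, at which 2 of the 4 values shown sit.

From the compounds shown here alone, whether dimethylamino and isopropylamino differ at all remains open, since neither gives a number in this assay. Also open, going by these compounds, is whether the chlorine of 4-chlorobenzyl counts here, which unsubstituted benzylamino or 4-fluorobenzylamino at this place would address.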